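This account rests on a few compounds, and the source may have more. Where it says the series, first, only, none or still open, it means among the compounds named here.

Measured in a functional assay on HeLa cells (Homo sapiens) for inhibition, read by MTT assay, with a stated time of 72 h (on this read-out higher numbers stand for weaker inhibition and lower numbers for stronger inhibition), so far:
compound 1 `CC(C)(C)c1ccc(C(=O)/C=C/C(=O)O)cc1` at 5100 nM
compound 2 `O=C(O)/C=C/C(=O)C1CCc2ccccc2C1` at 7010 nM
compound 3 `Cc1ccc(C(=O)/C=C/C(=O)O)c(Cl)c1` at 7600 nM

Compound 3 stands level with compound 1 and compound 2, since all three values lie within the scatter of one another. The next compound to be tested is compound 4 `O=C(O)/C=C/C(=O)c1ccc(Cl)cc1Cl`. It has chloro in place of methyl on an aromatic carbon, meta to a chloro group and para to a group of 7 heavy atoms (chloro in place of methyl on an aromatic carbon). Within the data shown here, no two measured compounds differ in one place only, so the series gives no direct step for this exchange. Even so, compound 1 at 5100 nM and compound 3 at 7600 nM stay within the scatter despite carrying different groups on the ring. No change beyond the scatter is therefore expected in this assay for this single exchange. The estimated step of a 1.2-fold lower number from compound 3 to compound 4 (0.07 log units; within the scatter) lies within the scatter. For compound 4 the estimate is 6500 nM with 3500 nM as the expected lower end and 12000 nM as the expected upper end of the range.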

Compound 4, half-maximal inhibitory concentration: 62900 nM
Compound 4: the middle estimate sits 9.7-fold (0.99 log units) below what was measured; the whole stated range lies below it.
By their numbers in this assay, from the lowest: compounds 1, 2 and 3 (each within the scatter of the next); then compound 4.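

In this assay, among these compounds, the exchange of methyl for chloro on this aromatic carbon, meta to a chloro group and para to a group of 7 heavy atoms, gives an 8.3-fold higher number from compound 3 to compound 4 (0.92 log units; beyond the scatter), the first step that can be read. Among the compounds shown here, this position therefore responds to a change of a single heavy atom, which the earlier compounds could not show, as no two of them differ in one place only. Nothing available explains the size of this step.

Going by these compounds, whether a methoxy group, an amine or a longer chain on this carbon would keep the number near that of compound 3 stays open. Also open, on these data alone, is whether the same exchange on another ring carbon, or without the other chloro group, would give a step of similar size.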